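Aryl sulfide hydroxypropanamides: trifluoromethoxy in place of trifluoromethyl

The source may report more compounds than this note shows. Statements on the series, on what has been measured and on what is new or still open speak of the compounds shown alone.

Measured so far:
Compound 1, `CC(O)(CSc1cccc(C(F)(F)F)c1)C(=O)Nc1ccc(S(F)(F)(F)(F)F)cc1`, gives 26200 nM in a functional assay on DU-145 cells (Homo sapiens) for antiproliferative activity, read by propidium iodide staining, with a stated time of 96 h; a lower number here means a stronger inhibitor, a higher number a weaker inhibitor.
Compound 2, `CC(O)(CSc1cccc(OC(F)(F)F)c1)C(=O)Nc1ccc(S(F)(F)(F)(F)F)cc1`, gives 23800 nM in this assay.
Compound 3, `CC(O)(CSc1ccc(C(F)(F)F)cc1)C(=O)Nc1cccc(S(F)(F)(F)(F)F)c1`, gives 27200 nM in this assay.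

Compound 2 differs from compound 1 by trifluoromethoxy in place of trifluoromethyl on an aromatic carbon, and the step is a 1.1-fold lower number from compound 1 to compound 2 (0.04 log units; within the scatter). Compound 3 has the same atoms as compound 1, joined differently; the difference between the two cores is not broken down here. The values of compound 1 and compound 3 lie within the scatter of each other, so no order between them is claimed.

Compound 4, `CC(O)(CSc1ccc(OC(F)(F)F)cc1)C(=O)Nc1cccc(S(F)(F)(F)(F)F)c1`, is not yet measured. Relative to compound 3 it carries trifluoromethoxy in place of trifluoromethyl on an aromatic carbon. This is the same kind of change as that from compound 1 to compound 2, not the same: there the group sits meta to a large group, here para to a large group. The step expected in this assay is a 1.1-fold lower number from compound 3 to compound 4 (0.04 log units; within the scatter), resting on the earlier step of a 1.1-fold lower number from compound 1 to compound 2 (0.04 log units; within the scatter), which stayed within the scatter. Compound 4 is therefore estimated at 25000 nM, expected between 12000 nM and 55000 nM.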

Compound 4, half-maximal inhibitory concentration: 24700 nM
For compound 4 the middle estimate is 1.0-fold (0.01 log units) above the measured one; the measured number falls inside the stated range.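

In this assay, trifluoromethoxy in place of trifluoromethyl gives a 1.1-fold lower number from compound 3 to compound 4 (0.04 log units; within the scatter), and this step matches the one seen on the core of compound 1: the same change on two cores in this assay, a 1.1-fold lower number (0.04 log units; within the scatter) from compound 1 to compound 2 and a 1.1-fold lower number (0.04 log units; within the scatter) from compound 3 to compound 4, 1.0-fold (0.00 log units) apart, within the scatter of two such steps On these two cores, the change therefore carries over as a step within the scatter, with the group para to a large group in compound 4. Among these compounds, this does not show that the change would stay this small on other cores or in other assays, as only two matched pairs are available.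

The compounds shown leave open whether an amine or a carboxylic acid in place of trifluoromethoxy would shift the number in this assay. Also open, as far as these compounds go, is what a longer chain in place of the methyl group on the hydroxypropanamide would do.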